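Methoxy for Fluoro on a Cytotoxicity Read-out

This account rests on a few compounds, and the source may have more. Where it says the series, first, only, none or still open, it means among the compounds named here.

Compound 1 `Fc1ccc(-c2cc(-c3ccc4cc(F)ccc4n3)nn2-c2ccccc2)cc1`: 89.7%
Compound 2 `COc1ccc(-c2cc(-c3ccc4cc(F)ccc4n3)nn2-c2ccccc2)cc1`: 93.7%
Compound 3 `Fc1ccc(-c2cc(-c3ccc4cc(F)ccc4n3)n(-c3ccc(F)cc3)n2)cc1`: 86.5%

Of the compounds shown here, three have been measured in an ADME assay on Huh-7 cells (Homo sapiens) for cytotoxicity, read by XTT assay, with a stated time of 3 days, tested at 200 uM; on this read-out higher numbers stand for a weaker effect at the one concentration tested and lower numbers for a stronger effect. Compound 1 gives 89.7%, and compound 2, which carries the change (methoxy in place of fluoro on an aromatic carbon), gives 93.7%. The step of a number 4 percentage points higher from compound 1 to compound 2 (within the scatter) is small, so the two readings cannot be told apart. Among the compounds with values here, compound 3 gives 86.5% in this assay; its readings against compound 1 and compound 2 also lie within the scatter, so no compound among the three can be called more or less cytotoxic than another. The difference between the core of compound 3 and the core of compound 1 is not broken down here.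

Compound 4 `COc1ccc(-c2cc(-c3ccc4cc(F)ccc4n3)n(-c3ccc(F)cc3)n2)cc1` has not yet been measured in this assay. It differs from compound 3 by methoxy in place of fluoro on an aromatic carbon, which is the same change as that from compound 1 to compound 2, made at the same place. Because the step of a number 4 percentage points higher from compound 1 to compound 2 (within the scatter) stayed within the scatter, the step from compound 3 to compound 4 is expected to be about as small, a number 3.5 percentage points higher from compound 3 to compound 4 (within the scatter). All three measured compounds sit near the top of the scale, which suggests a weak effect at this concentration across the set; compound 4 is therefore estimated to give 90% in this assay, with a likely range from 80% to 100%.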

Compound 4, a percentage reported as activity, at one concentration (the size of the read-out at that concentration, not a potency): 95.4%
For compound 4 the middle estimate is 5.4 percentage points below the measured one; low and high end bracket the measured number.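

In this assay, putting methoxy in place of fluoro on the second core gives a number 8.9 percentage points higher from compound 3 to compound 4 (within the scatter), so this step, like the one on the first core, cannot be told apart from the ordinary spread of repeated measurements. Set side by side, the two steps show no difference between the cores in how this change reads out: the same change on two cores in this assay, a number 4 percentage points higher (within the scatter) from compound 1 to compound 2 and a number 8.9 percentage points higher (within the scatter) from compound 3 to compound 4, 4.9 percentage points apart, within the scatter of two such steps. Within the data shown here, this shows only that the swap from 4-fluorophenyl to 4-methoxyphenyl left no effect that can be distinguished from scatter on either core; it does not show that methoxy weakens the cytotoxic effect, and two cores are too few to say that the same would hold on a third.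

The compounds shown leave open what a clearly different group in the same place, such as an amine, a carboxylic acid or a longer chain, would do to this reading. They also leave open whether the two cores would still behave alike at other concentrations, as each compound here has a single reading at one concentration, which is not a measure of potency.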